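The compounds below may be only part of what the source reports. "The series", "measured", "known", "first", "only" and "open" are said of these compounds alone.

Compound 1 `CCCCCCCn1cc(COC[C@@H]2OC[C@H](N)[C@@H]2O)nn1` and compound 2 `CCCCCCCCn1cc(COC[C@@H]2OC[C@H](N)[C@@H]2O)nn1` share one core and differ only in the chain attached to the aromatic nitrogen. In a functional assay on MCF7 cells (Homo sapiens) for antiproliferative activity, read by MTT assay, with a stated time of 48 h (on this read-out higher numbers stand for weaker inhibition and lower numbers for stronger inhibition), compound 1 gives a limit rather than a number, > 128000 nM; its standing therefore rests on (the limit of > 128000 nM in this assay, at which 1 of the 2 values shown sits). In this assay compound 2 gives 28100 nM. Among the measured compounds shown here, the single step between them, methyl in place of hydrogen on a saturated chain carbon, seven bonds along the chain from an aromatic nitrogen, reads an at least 4.5-fold lower number from compound 1 to compound 2 (0.65 log units; beyond the scatter). Compound 3 `CCCCCCCCCCCCCCCCn1cc(COC[C@@H]2OC[C@H](N)[C@@H]2O)nn1` is built from compound 1 by the change (nonyl in place of hydrogen on a saturated chain carbon, seven bonds along the chain from an aromatic nitrogen), the same direction of growth carried much further. For the measured compounds named here, the only measured step that bears on it is an at least 4.5-fold lower number from compound 1 to compound 2 (0.65 log units; beyond the scatter), which already points downward, so compound 3 is expected to show a further lowering in this assay, estimated as an at least 21-fold lower number from compound 1 to compound 3 (1.32 log units; beyond the scatter). Compound 3 is thus estimated at 6000 nM in this assay, within a range from 1200 nM to 30000 nM.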

Compound 3, half-maximal inhibitory concentration: 3300 nM
Compound 3: middle estimate off by 1.8-fold (0.26 log units), on the high side; measured number inside the range.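

The lowering at this position does not end with the first added methyl: in this assay, octyl in place of hydrogen on a saturated chain carbon, eight bonds along the chain from an aromatic nitrogen, gives an 8.5-fold lower number from compound 2 to compound 3 (0.93 log units; beyond the scatter). The whole nonyl change reads an at least 38-fold lower number from compound 1 to compound 3 (1.58 log units; beyond the scatter), so the number falls as the chain grows across all three compounds, and none of them goes against this order. Compound 1 has a limit and not a number, so this larger step is only a bound: the limit of > 128000 nM in this assay, at which 1 of the 3 values shown sits.

The compounds shown leave open whether the number keeps falling with a longer chain than that of compound 3, or how chains of intermediate length fit this order. They also leave open how a chain carrying an amine or a carboxylic acid would read.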